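Notes on the step from compound 2 to compound 3

A few compounds are considered here, and "the series" means these few. Any claim that something is new, unique, unknown or untested is made for them only; others in the source may bear on it.

Among the compounds with values here, in a functional assay on MDA-MB-231 cells (Homo sapiens) for inhibition, read by sulforhodamine B assay, with a stated time of 48 h (on this read-out lower numbers stand for stronger inhibition and higher numbers for weaker inhibition), compound 2 (`COc1ccc(C(c2ccc(O)cc2)c2cccc3ccccc23)c(OC)c1OC`) gives 17400 nM, the higher of the two numbers so far, while compound 1 (`COc1ccc(C(c2ccc(OC(C)CN(C)C)cc2)c2cccc3ccccc23)c(OC)c1OC`) gives 4340 nM. The next structure is compound 3 (`COc1ccc(C(OCc2ccc(C)cc2)c2cccc3ccccc23)c(OC)c1OC`), which has (4-methylbenzyl)oxy in place of 4-hydroxyphenyl on a saturated chain carbon bound to two aromatic carbons.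

Within the data shown here, only one measured step is available, a 4.0-fold higher number from compound 1 to compound 2 (0.60 log units; beyond the scatter). It is modest and beyond the scatter, but it concerns a different place: hydrogen in place of 1-((dimethylamino)methyl)ethyl on an oxygen on an aromatic ring. It therefore bears on the new change only indirectly, showing the size of shift seen so far within the series. Among the measured compounds shown here, no measured compound tests a change at the saturated chain carbon, so the data favour no direction. Compound 3 also lacks the 1-((dimethylamino)methyl)ethyl group, as does compound 2. No step beyond the scatter is therefore expected in this assay, and the estimated step is a 1.2-fold lower number from compound 2 to compound 3 (0.06 log units; within the scatter). For compound 3 the expected value is 15000 nM, with an estimated range of 5000 nM to 45000 nM.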

Compound 3, half-maximal inhibitory concentration: > 20000 nM
Compound 3: only a limit was reported (the forecaster's own chance of this, stated with the estimate: 15%); at least 1.3-fold (0.12 log units) between middle value and limit.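

In this assay compound 3 gives > 20000 nM, which is a limit of the assay and not a number: the limit of > 20000 nM in this assay, at which 1 of the 3 values shown sits.

Within the data shown here, the first reading at the saturated chain carbon bound to two aromatic carbons is an at least 1.1-fold higher number from compound 2 to compound 3 (0.06 log units; that floor lies within the scatter), so putting (4-methylbenzyl)oxy in place of 4-hydroxyphenyl yields no lower number on this read-out, and the floor of the step does not separate the two compounds. Neither compound 2 nor compound 3 carries the 1-((dimethylamino)methyl)ethyl group, so this change says nothing about how that group would act alongside (4-methylbenzyl)oxy.

How far compound 3 lies beyond its limit stays undetermined, which leaves the true size of the step open. Also open, on these data alone, is whether an amine such as the dimethylamino group of compound 1, or a carboxylic acid, built into the group on this saturated chain carbon would bring the number down.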